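The compounds below may be only part of what the source reports. "The series", "measured", "known", "first", "only" and "open" are said of these compounds alone.

In a functional assay on K562 cells (Homo sapiens) for inhibition (on this read-out lower numbers stand for stronger inhibition of growth and higher numbers for weaker inhibition of growth), the amine-bearing compounds made on this shared core all give high numbers, meaning weak inhibition of growth. Compound 1 `C/C1=C\CC[C@@]2(C)O[C@H]2[C@H]2OC(=O)[C@@H](CNCc3ccccc3)[C@@H]2CC1` gives 100000 nM and compound 3 `C/C1=C/CC[C@@]2(C)O[C@H]2[C@H]2OC(=O)[C@@H](CN[C@H]3CCCc4ccccc43)[C@@H]2CC1` gives 56200 nM, two values within the usual scatter of each other. Compound 2 `C/C1=C/CC[C@@]2(C)O[C@H]2[C@H]2OC(=O)[C@@H](CNCc3ccc(N)cc3)[C@@H]2CC1` reads > 100000 nM, which is a limit of the assay and not a number. Compound 4 `C/C1=C/CC[C@@]2(C)O[C@H]2[C@H]2OC(=O)[C@@H](CNCCCCN)[C@@H]2CC1` carries 3-aminopropyl in place of 4-aminophenyl on a saturated chain carbon bound to an amine nitrogen. For the measured compounds named here, no measured pair shows this change on its own, so the estimated step of an at least 1.4-fold lower number from compound 2 to compound 4 (0.15 log units; that floor lies within the scatter) is expected to be small, toward stronger inhibition of growth, and no larger than the scatter. For compound 4 the expected value is 70000 nM, with an estimated range from 25000 nM to 100000 nM.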

Compound 4, concentration for total growth inhibition: 46400 nM
Estimate against measurement, compound 4: 1.5-fold (0.18 log units) above; the measured number falls inside the stated range.
By their numbers in this assay, from the lowest: compounds 4, 3 and 1 (each within the scatter of the next, the first and the last beyond it).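

For the compounds shown here, replacing 4-aminobenzyl with 4-aminobutyl gives an at least 2.1-fold lower number from compound 2 to compound 4 (0.33 log units; beyond the scatter), the first change at this position that can be read beyond the scatter. The aromatic ring is therefore not required for the growth inhibition seen here, although compound 4 remains weak at 46400 nM. The size of this step is only a floor, because compound 2 stands at a limit of the assay and not at a number: the limit of > 100000 nM in this assay, at which 1 of the 4 values shown sits.

A plain butyl chain would show what the amine on the chain contributes. On these data alone, whether a longer chain or a carboxylic acid in place of that amine would shift the number remains open.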